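Shifting the fluoro group from compound 2 to compound 4

A few compounds are considered here, and "the series" means these few. Any claim that something is new, unique, unknown or untested is made for them only; others in the source may bear on it.

Measured so far in a functional assay on MIA PaCa-2 cells (Homo sapiens) for inhibition, read by MTT assay, with a stated time of 72 h (a lower number here means a stronger inhibitor, a higher number a weaker inhibitor), as follows:
Compound 1 `COc1cc(NC(C)CCCNC(=O)Nc2ccc(Br)cc2)c2ncccc2c1` gives 23000 nM
Compound 2 `COc1cc(NC(C)CCCNC(=O)NNC(=O)Nc2ccc(F)cc2)c2ncccc2c1` gives >= 250000 nM as a limit
Compound 3 `COc1cc(NC(C)CCCNC(=O)NNC(=O)Nc2ccc(C(F)(F)F)cc2)c2ncccc2c1` gives 19000 nM

Compound 2 stands at the limit of >= 250000 nM in this assay, at which 1 of the 3 values shown sits, and gives only that limit. Compound 4 `COc1cc(NC(C)CCCNC(=O)NNC(=O)Nc2cccc(F)c2)c2ncccc2c1` is its isomer, with the change 3-fluorophenyl in place of 4-fluorophenyl on an amide-type nitrogen putting 3-fluorophenyl in place of 4-fluorophenyl on an amide-type nitrogen. Among the compounds with values here, no measured step moves a group around this aromatic ring, so the evidence is indirect. The nearest guide is compound 3, where an at least 13-fold lower number from compound 2 to compound 3 (1.11 log units; beyond the scatter) shows that a change at this ring alone can be large. The step of an at least 10-fold higher number from compound 1 to compound 2 (1.03 log units; beyond the scatter) is also large but replaces more of the structure, so it bears less directly. A more modest shift than that seen for compound 3 seems likely, and only a lower number could be seen against the limit. The expected step is an at least 3.1-fold lower number from compound 2 to compound 4 (0.49 log units; beyond the scatter) with considerable uncertainty. The estimate for compound 4 is 80000 nM with an expected range of 20000 nM to 250000 nM and a real chance of another limit reading.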

Compound 4, half-maximal inhibitory concentration: 69000 nM
The estimate for compound 4 lay 1.2-fold (0.06 log units) above the measured number; the measured number falls inside the stated range.
By their numbers in this assay, from the lowest: compounds 3 and 1 (each within the scatter of the next); then compound 4. At a limit, above all of these: compound 2.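

In this assay, 3-fluorophenyl in place of 4-fluorophenyl gives an at least 3.6-fold lower number from compound 2 to compound 4 (0.55 log units; beyond the scatter), so the place of the fluoro group on this ring matters even with no atom added or lost. On these data alone, compound 2 remains a limit of the assay, so the full size of this step stays unknown: the limit of >= 250000 nM in this assay, at which 1 of the 4 values shown sits. Even so, 3-fluorophenyl does not match 4-(trifluoromethyl)phenyl, with a 3.6-fold higher number from compound 3 to compound 4 (0.56 log units; beyond the scatter), and ((3-fluorophenyl)carbamoyl)amino does not match 4-bromophenyl, with a 3.0-fold higher number from compound 1 to compound 4 (0.48 log units; beyond the scatter).

As far as these compounds go, it remains open whether a plain phenyl, or a chloro or nitrile group on this ring, would give a lower number than compound 4. Also open, from the compounds shown here alone, is how 3-fluorophenyl would behave directly on the amide-type nitrogen, where 4-bromophenyl sits in compound 1.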